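Chloro to Fluoro on Two Aminothiazole Ketone Cores

The source may hold more compounds than are shown below. What is called first, only, known or untested is meant among the compounds shown, and "the series" means these compounds.

Measured compounds: compound 1 `COc1cc(C(=O)c2sc(Nc3ccc(F)cc3)nc2N)cc(OC)c1OC` gives 58 nM; compound 3 `COc1cc(C(=O)c2sc(Nc3ccc(Cl)cc3)nc2N)cc(OC)c1OC` gives 420 nM; compound 2 `Nc1nc(Nc2ccc(Cl)cc2)sc1C(=O)c1ccccc1` gives > 10000 nM.

These three were tested in a functional assay on FM3A cells (Mus musculus) for antiproliferative activity, read by cell counting, with a stated time of 2 days; a higher number here means a weaker inhibitor, a lower number a stronger inhibitor. Compound 2 reaches only a limit of this assay, > 10000 nM, which marks (the limit of > 10000 nM in this assay, at which 1 of the 3 values shown sits). Compound 3 and compound 1 share a core and differ by fluoro in place of chloro on an aromatic carbon; this gave a 7.2-fold lower number from compound 3 to compound 1 (0.86 log units; beyond the scatter). The difference between the core of compound 2 and the core of compound 3 is not broken down here. Compound 4 `Nc1nc(Nc2ccc(F)cc2)sc1C(=O)c1ccccc1` is still to be measured; it differs from compound 2 by fluoro in place of chloro on an aromatic carbon, the same change as that from compound 3 to compound 1. Compound 4 is expected to give an at least 1.6-fold lower number from compound 2 to compound 4 (0.22 log units; that floor lies within the scatter), since compound 2 sits at a limit, > 10000 nM, and the earlier step of a 7.2-fold lower number from compound 3 to compound 1 (0.86 log units; beyond the scatter) is only modest. Compound 4 is estimated at 6000 nM, within 1000 nM to 40000 nM.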

Compound 4, half-maximal inhibitory concentration: > 10000 nM
Compound 4 ended at the assay's limit (the forecaster's own chance of this, stated with the estimate: 45%); middle value at least 1.6-fold (0.22 log units) from the limit.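

No step from compound 2 to compound 4 can be read, because both stand at a limit of this assay: the limit of > 10000 nM in this assay, at which 2 of the 4 values shown sit.

The compounds shown leave open whether fluoro in place of chloro has any effect on the core of compound 2.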